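Series notes: fluoro variant of compound 1

A few compounds are considered here, and "the series" means these few. Any claim that something is new, unique, unknown or untested is made for them only; others in the source may bear on it.

Measured so far:
compound 1 `O=C(NC(=S)NCc1ccccc1)c1ccccc1`: "not active" (no number reported)
compound 2 `O=C(NC(=S)NCc1cc(C(F)(F)F)cc(C(F)(F)F)c1)c1ccccc1`: 10%
compound 3 `O=C(NC(=S)NCc1ccc(C(F)(F)F)cc1)c1ccccc1`: "not active" (no number reported)

In an assay on isolated protein for inhibition of protein deacetylase HDAC6 (Homo sapiens), read by fluorescence, tested at 100 uM (on this read-out lower numbers stand for less inhibition and higher numbers for more inhibition at the one concentration tested (going by the name of the read-out)), compound 1 gives "not active" (no number reported), so no single number stands for it; compound 3 likewise gives "not active" (no number reported). Only compound 2 returns a number, 10%, a small value. For the measured compounds named here, no steps between measured compounds are known, so no measured change can be placed against the one considered here. Compound 4 `O=C(NC(=S)NCc1ccccc1)c1ccccc1F` differs from compound 1 by fluoro in place of hydrogen on an aromatic carbon. Nothing measured shows what such a change does; the expected step in this assay is none beyond the scatter, with inhibition staying low. Compound 4 is therefore expected to give 3%, within a range from 0% to 12%, and a report of no activity remains the likelier outcome.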

Compound 4, a percentage reported as inhibition, at one concentration (the size of the read-out at that concentration, not a potency): "not active" (no number reported)
Compound 4: no number reported; the estimate stays without a comparison.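

No step can be read between compound 1 and compound 4: in this assay compound 1 gives "not active" (no number reported) and compound 4 gives "not active" (no number reported) as well. The compounds shown leave open whether fluoro in place of hydrogen changes inhibition at all. No evidence bears on this result.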